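Chloro Substitution on Two Aryl Cores of a Shared Scaffold

This account rests on a few compounds, and the source may have more. Where it says the series, first, only, none or still open, it means among the compounds named here.

The measured compounds:
compound 1, `c1ccc(-c2cc3n(n2)CCCC3)nc1`, 1290 nM
compound 2, `Clc1cccc(-c2cc3n(n2)CCCC3)n1`, 1520 nM
compound 3, `c1ccc(-c2cc3n(n2)CCCC3)cc1`, 1900 nM

These three compounds share a bicyclic core and differ only in the six-membered aromatic ring attached to it. In a functional assay on HEK293 cells for negative allosteric modulation of metabotropic glutamate receptor 5 (Rattus norvegicus), read by FLIPR and calcium flux, with a stated time of 170 s (on this read-out higher numbers stand for weaker inhibition and lower numbers for stronger inhibition), compound 1 gives 1290 nM, compound 2 gives 1520 nM and compound 3 gives 1900 nM. All three values lie within the scatter of one another, so no order among them can be read from these numbers.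

The step from compound 1 to compound 2 is chloro in place of hydrogen on an aromatic carbon, and it produced a 1.2-fold higher number from compound 1 to compound 2 (0.07 log units; within the scatter). The difference between the cores of compound 1 and compound 3 is not broken down here.

Compound 4, `Clc1ccccc1-c1cc2n(n1)CCCC2`, has not yet been measured in this assay. Its relation to compound 3 is chloro in place of hydrogen on an aromatic carbon. This is the same kind of change as that from compound 1 to compound 2, but the surroundings differ: in compound 2 the chloro sits on a six-membered aromatic ring with 1 nitrogen, next to the ring nitrogen, meta to a group of 9 heavy atoms, whereas in compound 4 it sits on a six-membered aromatic ring of carbon only, ortho to a group of 9 heavy atoms.

Because the earlier chloro step gave a 1.2-fold higher number from compound 1 to compound 2 (0.07 log units; within the scatter), an effect within the scatter, the step from compound 3 to compound 4 is expected to be of similar small size, a 1.2-fold higher number from compound 3 to compound 4 (0.06 log units; within the scatter), with added uncertainty from the different surroundings. Compound 4 is therefore estimated at 2200 nM, likely between 1000 nM and 5000 nM.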

Compound 4, half-maximal inhibitory concentration: 2650 nM
Compound 4: middle estimate off by 1.2-fold (0.08 log units), on the low side, within the range that was stated.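

In this assay, chloro in place of hydrogen on an aromatic carbon of the ring of carbon only, ortho to a group of 9 heavy atoms, gave a 1.4-fold higher number from compound 3 to compound 4 (0.14 log units; within the scatter) and so stays, like the earlier chloro step, inside the usual variation of this measurement. Set side by side, the two steps show no difference that can be read, so in these two pairs the change carries from one core to the other without a detectable shift in its effect: the same change on two cores in this assay, a 1.2-fold higher number (0.07 log units; within the scatter) from compound 1 to compound 2 and a 1.4-fold higher number (0.14 log units; within the scatter) from compound 3 to compound 4, 1.2-fold (0.07 log units) apart, within the scatter of two such steps. This does not show that the effect of chloro is the same on both cores or that it would hold elsewhere in the series, since the two pairs differ in the surroundings of the chloro as well as in the core, and steps this small cannot separate those two factors or support a rule.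

What the compounds shown leave open is whether a group other than chloro on these aromatic rings, such as a methoxy, an amine or a carboxylic acid, would move the number beyond the scatter. Also open, on these data alone, is how the same rings would behave if the shared core itself carried a substituent, such as a methyl group or a longer chain.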